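Adding a methyl to the phenyl ring: what to expect

The compounds below may be only part of what the source reports. "The series", "measured", "known", "first", "only" and "open" are said of these compounds alone.

Two compounds set the scene. Compound 1, `COc1cc(C(=O)NNC(=S)Nc2csc(-c3ccc(C)cc3)c2)cc(OC)c1OC`, carries a trimethoxy-substituted amide and a 4-methylphenyl on the thiophene end; compound 2, `COc1cc(OC)cc(C(=O)NNC(=S)Nc2csc(-c3ccccc3)c2)c1`, carries two methoxy groups on the amide side and an unsubstituted phenyl. In a functional assay on A549 cells (Homo sapiens) for inhibition, read by colorimetric assay and MTT assay, with a stated time of 72 h (a higher number here means a weaker inhibitor, a lower number a stronger inhibitor), compound 1 gives 39000 nM. In this assay compound 2 gives 39000 nM, level with compound 1 at the digits shown and within the usual scatter, so no difference between them can be claimed.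

Compound 3, `COc1cc(OC)cc(C(=O)NNC(=S)Nc2csc(-c3ccc(C)cc3)c2)c1`, keeps the dimethoxy amide of compound 2 and changes only the phenyl: methyl in place of hydrogen on an aromatic carbon. Within the data shown here, no measured pair shows this exact change on its own. The two measured values, both weak and indistinguishable, give no sign that the methyl matters here, so the step from compound 2 to compound 3 is expected to be no change beyond the scatter, no change at the digits printed from compound 2 to compound 3 (within the scatter). Compound 3 is therefore estimated to give 39000 nM in this assay, with a plausible range from 15000 nM to 100000 nM.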

Compound 3, half-maximal inhibitory concentration: 32000 nM
Beside the measured number, compound 3's estimate is 1.2-fold (0.09 log units) above it, within the range that was stated.
By their numbers in this assay, from the lowest: compounds 3, 1 and 2 (each within the scatter of the next).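

Going from phenyl to 4-methylphenyl gives a 1.2-fold lower number from compound 2 to compound 3 (0.09 log units; within the scatter) in this assay, so this single methyl, now seen on its own, cannot be told apart from hydrogen at this position. The new compound also provides a second single change, on the other side of the molecule: hydrogen in place of methoxy on an aromatic carbon gives a 1.2-fold lower number from compound 1 to compound 3 (0.09 log units; within the scatter), so that methoxy likewise makes no readable difference here. No independent measurement is available to explain why these changes leave the number within the scatter.

The compounds shown cover only hydrogen and methyl on the phenyl, so it remains open whether an amine, a carboxylic acid or a longer chain such as butyl at that spot would move the number beyond the scatter. From the compounds shown here alone, it also remains open whether the two remaining methoxy groups matter, as would be tested by replacing them with hydroxyl groups or with chlorine atoms, since a single small change with no readable effect says little about larger changes.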